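This account rests on a few compounds, and the source may have more. Where it says the series, first, only, none or still open, it means among the compounds named here.

Among the measured compounds shown here, compound 1 `C=CC1=C(C(=O)NCCCCC)C(c2ccc(Cl)c(Cl)c2)OC1` gives 27500 nM in a functional assay on SW480 cells (Homo sapiens) for cytotoxicity, read by MTT assay, with a stated time of 24 h (a lower number here means a stronger inhibitor, a higher number a weaker inhibitor), and is the only member of the series for which a number, rather than a limit, is reported. Compound 2 `C=CC1=C(C(=O)O)C(c2ccc(OC)cc2)OC1` reaches only a limit of this assay, namely > 100000 nM. Compound 3 `C=CC1=C(C(=O)NC(C)(C)C)C(c2ccc(F)cc2)OC1` likewise returns a limit, > 100000 nM. For the measured compounds named here, compound 1 therefore stands alone as the one measured number, with the limit of > 100000 nM in this assay, at which 2 of the 3 values shown sit, holding the remaining two. Compound 4 `C=CC1=C(C(=O)NCc2ccccc2)C(c2ccc(Cl)c(Cl)c2)OC1` is not yet measured and differs from compound 1 by phenyl in place of butyl on a saturated chain carbon bound to an amide-type nitrogen. Going by the values given here, no measured pair differs in a single place, so no step size is available to lean on. For compound 4 the expected step is a 1.1-fold lower number from compound 1 to compound 4 (0.04 log units; within the scatter), nothing beyond the usual scatter. Compound 4 is thus estimated at 25000 nM in this assay, within 8000 nM to 90000 nM.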

Compound 4, half-maximal inhibitory concentration: > 100000 nM
Compound 4 gave a limit, no number; the forecaster's own chance of this, stated with the estimate: 30%; at least 4.0-fold (0.60 log units) between middle value and limit.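

Among the compounds shown here, at this position, on a saturated chain carbon bound to an amide-type nitrogen, phenyl in place of butyl gives an at least 3.6-fold higher number from compound 1 to compound 4 (0.56 log units; beyond the scatter) in this assay and provides the first single-place comparison. The pentyl chain of compound 1 therefore remains the only amide substituent here with a number rather than a limit. Compound 4 sits at a limit of the assay, not a number: the limit of > 100000 nM in this assay, at which 3 of the 4 values shown sit.

Open, from the compounds shown here alone, is whether a longer chain, such as hexyl, would lower the number further. Also open, going by these compounds, is whether a chain ending in an amine or a carboxylic acid would keep a measurable value.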